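Capping the Terminal Amine of Compound 3

A few compounds are considered here, and "the series" means these few. Any claim that something is new, unique, unknown or untested is made for them only; others in the source may bear on it.

Compound 1 `NCCCCN(C[C@H]1Cc2ncccc2CN1)[C@H]1CCCc2cccnc21` gives 86% in an ADME assay on microsomes from liver (Mus musculus) for metabolic stability, using NADPH, with a stated time of 10 min; a lower number here means that less of the compound is left, a higher number that more of the compound is left
Compound 2 `NCCCCN(C[C@@H]1Cc2cccnc2CN1)[C@H]1CCCc2cccnc21` gives 25%
Compound 3 `NC/C=C\CN(C[C@H]1Cc2ncccc2CN1)[C@H]1CCCc2cccnc21` gives 37%

Compound 3 (37%) holds the middle place of the three numbers, with both gaps beyond the scatter: it lies above compound 2 and far below compound 1. Compound 4 `NC(=O)NC/C=C\CN(C[C@H]1Cc2ncccc2CN1)[C@H]1CCCc2cccnc21` differs from compound 3 by carbamoyl in place of hydrogen on an amine nitrogen, with carbamoyl in place of hydrogen on an amine nitrogen, so that amino becomes ureido. Going by the values given here, only one measured step touches this chain, a number 49 percentage points lower from compound 1 to compound 3 (beyond the scatter), and it is large. That step is a different change, however, namely 3-aminoprop-1-en-1-yl in place of 3-aminopropyl. Among the compounds with values here, it shows that the number can move far when the chain changes, but no measured step replaces amino with ureido, so the data fix neither size nor direction. The central expectation is therefore no step beyond the scatter, with a wide margin on either side. The expected outcome is a number 5 percentage points higher from compound 3 to compound 4 (within the scatter) (an estimate only). For compound 4 the estimated value is 42% (expected range 20% to 68%).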

Compound 4, percent of the compound remaining: 10%
For compound 4 the middle estimate is 32 percentage points above the measured one; the measured number lies below the stated range.
By their numbers in this assay, from the lowest: compound 4; then compound 2; then compound 3; then compound 1.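

In this assay, carbamoyl in place of hydrogen on the amine nitrogen gives a number 27 percentage points lower from compound 3 to compound 4 (beyond the scatter), so the number responds to a change at the amine nitrogen itself, whereas the earlier step changed only the chain that carries it. Together, the changes to the chain and to its amine nitrogen give a number 76 percentage points lower from compound 1 to compound 4 (beyond the scatter), and amino to ureido moves the number further in the direction already set by a number 49 percentage points lower from compound 1 to compound 3 (beyond the scatter). No measured evidence is available to account for this fall.

It remains open whether the fall belongs to the ureido group in general or only to ureido on this unsaturated chain, as the compounds shown do not pair ureido with the 3-aminopropyl chain of compound 1. From the compounds shown here alone, it is equally open how an acetyl group or a methyl group on the same amine nitrogen would read.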